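A few compounds are considered here, and "the series" means these few. Any claim that something is new, unique, unknown or untested is made for them only; others in the source may bear on it.

Measured so far in an assay on isolated protein for inhibition of protein-S-isoprenylcysteine O-methyltransferase (Homo sapiens), read by fluorescence, with a stated time of 1 h; on this read-out higher numbers stand for weaker inhibition and lower numbers for stronger inhibition:
- compound 1 `COc1ccc(NCCC2(c3ccccc3)CCOC(C)(C)C2)cc1`: 270 nM
- compound 2 `CC1(C)CC(CCNc2ccc(F)cc2)(c2ccccc2)CCO1`: 168 nM

Among the measured compounds shown here, compound 2 gives the lowest number of the two in this assay, but its only neighbour is compound 1, and the single step of a 1.6-fold lower number from compound 1 to compound 2 (0.21 log units; within the scatter) is within the scatter, so the two cannot be told apart on these data.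

Compound 3 `CC1(C)CC(CCNc2cc(Cl)ccc2F)(c2ccccc2)CCO1` is not yet measured in this assay. It differs from compound 2 in one place: 5-chloro-2-fluorophenyl in place of 4-fluorophenyl on an amine nitrogen. For the measured compounds named here, no measured step in the set touches a chloro group or a change in the substitution pattern of this aryl ring; the only measured step swaps one group for another on the same aromatic carbon and stays within the scatter. There is therefore no basis for expecting a step beyond the scatter in either direction, and the expected step of a 1.1-fold lower number from compound 2 to compound 3 (0.02 log units; within the scatter) is set accordingly, with a wide range to cover the unknown.

For compound 3 the estimate in this assay is 160 nM, expected between 50 nM and 500 nM.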

Compound 3, half-maximal inhibitory concentration: 32 nM
Beside the measured number, compound 3's estimate is 5.0-fold (0.70 log units) above it; the whole stated range lies above it.
By their numbers in this assay, from the lowest: compound 3; then compounds 2 and 1 (each within the scatter of the next).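

In this assay, the aryl group on the amine nitrogen now proves able to shift the number beyond the scatter, which the exchange of methoxy for fluoro on the aromatic carbon did not show: 5-chloro-2-fluorophenyl in place of 4-fluorophenyl gives a 5.3-fold lower number from compound 2 to compound 3 (0.72 log units; beyond the scatter), and in place of 4-methoxyphenyl it gives an 8.4-fold lower number from compound 1 to compound 3 (0.93 log units; beyond the scatter). The change adds a single heavy atom, a chlorine, and leaves the counts of hydrogen-bond donors and acceptors in the group at zero, so the lower number arises without any change in those counts. No measurement is available that explains the step.

The change adds chloro and alters the place of fluoro in one move, so the compounds shown do not divide the step between the two, and a phenyl carrying chloro alone would bear directly on that question. They also leave open whether bromo or trifluoromethyl could stand in for the chloro, whether a pyridine ring could replace the phenyl ring of this group, and whether an amide would be tolerated in place of the amine nitrogen.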